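The compounds below may be only part of what the source reports. "The series", "measured", "known", "first", "only" and "open" are said of these compounds alone.

Measured so far in an ADME assay on the whole organism with Oryza sativa as the target, tested at 0.1 uM; a higher number here means a weaker effect of the compound at the concentration tested, a lower number a stronger effect:
- compound 1, `CCCCc1ccc(NC(=O)N[C@H](C)c2ccccc2)cc1`, gives 100%
- compound 2, `CCOC(=O)c1ccc(NC(=O)N[C@H](C)c2ccccc2)cc1`, gives 101%
- compound 3, `CC(=O)c1ccc(NC(=O)N[C@H](C)c2ccccc2)cc1`, gives 96%

The three compounds share one core and differ only in the group carried on an aromatic carbon. Compound 3 sits close to both of the others: the step of a number 4 percentage points lower from compound 1 to compound 3 (within the scatter) and the step of a number 5 percentage points lower from compound 2 to compound 3 (within the scatter) are each small, so compound 3 cannot be told apart from either on these numbers.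

The next compound, compound 4, `C[C@@H](NC(=O)Nc1ccc(F)cc1)c1ccccc1`, differs from compound 3 in one place:
fluoro in place of acetyl on an aromatic carbon

Two of the measured steps exchange groups at that same aromatic carbon and therefore bear most on this change: a number 1 percentage points higher from compound 1 to compound 2 (within the scatter) and a number 4 percentage points lower from compound 1 to compound 3 (within the scatter), neither of which left the scatter. The third step, a number 5 percentage points lower from compound 2 to compound 3 (within the scatter), alters only the carbonyl group and was likewise small. Among the measured compounds shown here, no measured step exchanges acetyl for fluoro directly, so the expectation rests on these three. Because every swap at this aromatic carbon so far gave a number 1 percentage points higher from compound 1 to compound 2 (within the scatter) or a number 4 percentage points lower from compound 1 to compound 3 (within the scatter), the expected step is a number 2 percentage points higher from compound 3 to compound 4 (within the scatter), with no movement beyond the scatter. Compound 4 is therefore estimated at 98%, with a likely range from 88% to 108%.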

Compound 4, a percentage reported as activity, at one concentration (the size of the read-out at that concentration, not a potency): 98%
The estimate for compound 4 equals the measured number at the digits printed; the measured number falls inside the stated range.
By their numbers in this assay, from the lowest: compounds 3, 4, 1 and 2 (each within the scatter of the next).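

In this assay the exchange of acetyl for fluoro, a group of a single heavy atom with no hydrogen-bond acceptor, produces no change that can be told from the scatter (a number 2 percentage points higher from compound 3 to compound 4 (within the scatter)). The same holds when fluoro is compared with the two other groups at this aromatic carbon, para to a large group (a number 3 percentage points lower from compound 2 to compound 4 (within the scatter); a number 2 percentage points lower from compound 1 to compound 4 (within the scatter)), so butyl, ethoxycarbonyl, acetyl and fluoro cannot be separated from one another by this read-out. No supporting measurement is available to explain this result.

These four compounds leave open whether any group at this carbon can move the number beyond the scatter, for example an amine, a carboxylic acid or a chain longer than butyl. They also leave open whether changes elsewhere on the shared core, such as a substituent on its other aromatic ring or a replacement of the urea carbonyl, would affect the read-out, since every compound here differs only at this one carbon.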